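A few compounds are considered here, and "the series" means these few. Any claim that something is new, unique, unknown or untested is made for them only; others in the source may bear on it.

Working notes on the series. Of the compounds shown here, three are measured so far: compound 1 `CCN(Cc1ccoc1)C(=O)COc1ccc(C)cc1`, compound 2 `CCN(Cc1cccs1)C(=O)c1cc2cc(C)ccc2o1` and compound 3 `Cc1ccc(OCC(=O)N(Cc2cccs2)c2ncccn2)cc1`. In an assay on HEK293 cells for agonist activity at transient receptor potential cation channel subfamily M member 8 (Homo sapiens), read by fluorescence and calcium flux, with a stated time of 15 min (on this read-out lower numbers stand for an effect already at smaller amounts and higher numbers for an effect only at larger amounts of compound), compound 1 gives 136 nM and compound 2 gives 120 nM; these two values lie within the scatter of each other. In this assay compound 3 gives 3700 nM, the highest number of the three, and its gaps to compound 1 and to compound 2 both lie well beyond the scatter. Compound 4 `Cc1ccc(OCC(=O)N(Cc2cccs2)c2ccn(C)n2)cc1` is not yet measured. It differs from compound 3 in one place: 1-methyl-1H-pyrazol-3-yl in place of pyrimidin-2-yl on an amide-type nitrogen. Among the measured compounds shown here, no measured pair shows an exchange of this kind, so no measured step guides it. A step of a 1.5-fold lower number from compound 3 to compound 4 (0.17 log units; within the scatter) is expected, a modest move toward a lower number that may stay within the scatter. For compound 4 a value of 2500 nM is estimated in this assay, with a range from 800 nM to 8000 nM.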

Compound 4, half-maximal effective concentration: 855 nM
For compound 4 the middle estimate is 2.9-fold (0.47 log units) above the measured one; the range from low to high includes it.
By their numbers in this assay, from the lowest: compounds 2 and 1 (each within the scatter of the next); then compound 4; then compound 3.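

Among the compounds shown here, at the amide-type nitrogen, the ring carried there matters in this assay: 1-methyl-1H-pyrazol-3-yl in place of pyrimidin-2-yl gives a 4.3-fold lower number from compound 3 to compound 4 (0.64 log units; beyond the scatter), the first measured single-place step. The two groups have equal counts of heavy atoms, hydrogen-bond donors and acceptors, and neither carries a net charge, yet the numbers differ beyond the scatter. Nothing measured explains this step.

Open, on these data alone, is whether the lower number follows the five-membered ring or its methyl group. Also open, as far as these compounds go, is how a plain phenyl ring or an unmethylated 1H-pyrazol-3-yl would read at this place.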